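Bromine to Chlorine on a Shared Fused Ring

The source may report more compounds than this note shows. Statements on the series, on what has been measured and on what is new or still open speak of the compounds shown alone.

Three compounds from one series were examined in a functional assay on cells (Melanoma cell, Homo sapiens) for cytotoxicity, read by sulforhodamine B assay, with a stated time of 48 h; a higher number here means a weaker inhibitor of growth, a lower number a stronger inhibitor of growth. Compound 1 `COc1ccc(C2=NN(C3=NC(=O)/C(=C4\C(=O)Nc5ccc(Br)cc54)S3)C(c3ccc(Cl)cc3)C2)cc1` gives 160 nM in this assay. Compound 2 `COc1ccc(C2=NN(C3=NC(=O)/C(=C4\C(=O)Nc5ccc(Cl)cc54)S3)C(c3ccc(Cl)cc3)C2)cc1` gives 200 nM in this assay. The two differ in one place, (chloro in place of bromo on an aromatic carbon), and that change brought a 1.3-fold higher number from compound 1 to compound 2 (0.10 log units; within the scatter).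

Compound 3 `CN(C)c1ccc(C2CC(c3ccccc3)=NN2C2=NC(=O)/C(=C3\C(=O)Nc4ccc(Br)cc43)S2)cc1` has a different core; the difference between the core of compound 1 and the core of compound 3 is not broken down here. In this assay compound 3 gives 200 nM, level with compound 2 at the digits printed, and its number and that of compound 1 lie within the scatter of each other.

Compound 4 `CN(C)c1ccc(C2CC(c3ccccc3)=NN2C2=NC(=O)/C(=C3\C(=O)Nc4ccc(Cl)cc43)S2)cc1` has not yet been measured. It stands to compound 3 as compound 2 stands to compound 1: the change is chloro in place of bromo on an aromatic carbon, the same change at the same kind of place, occurring twice among these compounds. Because the first instance gave a 1.3-fold higher number from compound 1 to compound 2 (0.10 log units; within the scatter), the account expects a step of similar size from compound 3 to compound 4, namely a 1.3-fold higher number from compound 3 to compound 4 (0.10 log units; within the scatter), with the caution that a single earlier example, itself within the scatter, is a thin basis. For compound 4 in this assay the account therefore estimates 250 nM, with a likely range from 130 nM to 500 nM.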

Compound 4, concentration for 50% growth inhibition: 260 nM
Estimate against measurement, compound 4: 1.0-fold (0.02 log units) below, and the stated range covers the measured number.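

In this assay, chloro in place of bromo on the second core brings a 1.3-fold higher number from compound 3 to compound 4 (0.11 log units; within the scatter), and this step matches the earlier one: the same change on two cores in this assay, a 1.3-fold higher number (0.10 log units; within the scatter) from compound 1 to compound 2 and a 1.3-fold higher number (0.11 log units; within the scatter) from compound 3 to compound 4, 1.0-fold (0.02 log units) apart, within the scatter of two such steps. Within these four compounds, then, the change carries from the core of compound 1 to the core of compound 3 with a step of much the same size, and the two cores give no sign of treating it differently. Each step on its own lies within the scatter, however, so the pairs do not show that the exchange of these two halogens makes a real difference to growth inhibition, and two cores cannot establish a rule for the whole series.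

The compounds shown carry only bromo or chloro at this place on the fused ring, which leaves open how fluoro, an amine or a carboxylic acid there would read in this assay. As far as these compounds go, it also remains open whether the bromo and chloro pair would stay as close on a core carrying a longer chain on one of its outer aromatic rings.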